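The source may report more compounds than this note shows. Statements on the series, on what has been measured and on what is new or still open speak of the compounds shown alone.

Measured so far in a functional assay on HeLa cells (Homo sapiens) for antiproliferative activity, read by CCK-8 assay, with a stated time of 48 h; a higher number here means a weaker inhibitor, a lower number a stronger inhibitor: compound 1 `COc1ccc(/C=C\c2cc(OC)c(OC)c(OC)c2)cc1OCc1ccc(CN2CCCCC2C(=O)O)cc1` gives 14200 nM; compound 2 `COc1ccc(/C=C\c2cc(OC)c(OC)c(OC)c2)cc1OCc1ccc(CN2CC(C(=O)O)C2)cc1` gives 6500 nM.

Compound 2 stands lowest of the two numbers, with compound 1 the nearest neighbour: a 2.2-fold lower number from compound 1 to compound 2 (0.34 log units; beyond the scatter). From the compounds shown here alone, compound 3 `COc1ccc(/C=C\c2cc(OC)c(OC)c(OC)c2)cc1OCc1ccc(CN2CCCCC2C(=O)NCCN)cc1` is untested. The change from compound 2 is 2-((2-aminoethyl)carbamoyl)piperidin-1-yl in place of 3-carboxyazetidin-1-yl on a saturated chain carbon bound to an aromatic carbon. Among the compounds with values here, only the step from compound 1 to compound 2 bears on it, and only in part, since it brings the six-membered ring of compound 1 back while the acid is gone. Compound 3 is therefore expected to show a modest rise, a 1.8-fold higher number from compound 2 to compound 3 (0.27 log units; within the scatter), with an estimate of 12000 nM and a range from 4000 nM to 40000 nM.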

Compound 3, half-maximal inhibitory concentration: 7300 nM
Compound 3: the middle estimate sits 1.6-fold (0.22 log units) above what was measured, within the range that was stated.
By their numbers in this assay, from the lowest: compounds 2, 3 and 1 (each within the scatter of the next, the first and the last beyond it).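

In this assay, (2-aminoethyl)amino in place of hydroxy on a carbonyl carbon gives a 1.9-fold lower number from compound 1 to compound 3 (0.29 log units; within the scatter), so replacing the carboxylic acid of compound 1 with this amide leaves the difference within the scatter. On the saturated chain carbon bound to an aromatic carbon, 2-((2-aminoethyl)carbamoyl)piperidin-1-yl in place of 3-carboxyazetidin-1-yl gives a 1.1-fold higher number from compound 2 to compound 3 (0.05 log units; within the scatter), so this position tolerates the larger group without a carboxylic acid. Nothing available explains either step.

From the compounds shown here alone, whether a longer chain or a tertiary amine on the amide would move the number beyond the scatter remains open. So does how the same (2-aminoethyl)amino group would behave on the four-membered ring.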